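The source may report more compounds than this note shows. Statements on the series, on what has been measured and on what is new or still open speak of the compounds shown alone.

Going by the values given here, compound 1 `CSc1nc2sncc2n1[C@H]1C[C@H](O)[C@@H](CO)O1` gives 20000 nM in a functional assay on L1210 cells (Mus musculus) for antiproliferative activity (a lower number here means a stronger inhibitor, a higher number a weaker inhibitor), the higher of the two numbers measured so far. Compound 2 `OC[C@H]1O[C@@H](n2c(SCc3ccccc3)nc3sncc32)C[C@@H]1O` gives 2200 nM, and the step of a 9.1-fold lower number from compound 1 to compound 2 (0.96 log units; beyond the scatter) is the only measured one. Compound 3 `CSc1nc2sncc2n1[C@@H]1O[C@H](CO)[C@@H](O)[C@@H]1O` differs from compound 1 by hydroxy in place of hydrogen on a saturated ring carbon. Among the compounds with values here, the measured step alters the group on the sulfur, not the five-membered non-aromatic ring, so no measured step bears on this change. Compound 3 is therefore expected to show a step of no change at the digits printed from compound 1 to compound 3 (within the scatter) that stays within the scatter. The estimate for compound 3 is 20000 nM, with a range from 5000 nM to 80000 nM.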

Compound 3, half-maximal inhibitory concentration: 11000 nM
Compound 3: the middle estimate sits 1.8-fold (0.26 log units) above what was measured, and the stated range covers the measured number.
By their numbers in this assay, from the lowest: compound 2; then compounds 3 and 1 (each within the scatter of the next).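

In this assay, hydroxy in place of hydrogen on this saturated ring carbon gives a 1.8-fold lower number from compound 1 to compound 3 (0.26 log units; within the scatter) and so leaves compounds 1 and 3 within the scatter of each other. Going by these compounds alone, this is the first measured step on the five-membered non-aromatic ring, and it shows that this position takes a hydroxy group without a difference beyond the scatter. Nothing available explains this result. Going by these compounds, it remains open whether the hydroxy group would give the same outcome with the phenyl group of compound 2 in place, and whether an amine or a fluorine atom on this ring carbon would do so.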